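Acid to Ethyl Ester: An Expected Gain in Cell Potency

A few compounds are considered here, and "the series" means these few. Any claim that something is new, unique, unknown or untested is made for them only; others in the source may bear on it.

Compound 1 `C=CC(=O)Nc1ccc(Cn2nc(-c3ccc(Oc4ccccc4)cc3)cc2C(=O)O)cc1`: > 60000 nM
Compound 2 `CCOC(=O)c1cc(-c2ccc(Oc3ccccc3)cc2)nn1Cc1cccc(NC(=O)CCl)c1`: 400 nM
Compound 3 `C/C=C/C(=O)Nc1cccc(Cn2nc(-c3ccc(Oc4ccccc4)cc3)cc2C(=O)O)c1`: 26000 nM

In a functional assay on Rec1 cells (Homo sapiens) for inhibition, read by luminescence and CellTiter-Glo, with a stated time of 72 h (a lower number here means a stronger inhibitor, a higher number a weaker inhibitor), compound 3 gives 26000 nM, the highest of the two values that are actual numbers. Compound 2 gives 400 nM, far lower, and that gap lies well beyond the usual scatter. The value of compound 1, > 60000 nM, is a limit of the assay rather than a number (the limit of > 60000 nM in this assay, at which 1 of the 3 values shown sits). Going by the values given here, compound 2 and compound 3 differ in more than one place, so no single step connects them; their two values show only that the compound carrying the ethyl ester sits at the much lower number.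

Compound 4 `C/C=C/C(=O)Nc1cccc(Cn2nc(-c3ccc(Oc4ccccc4)cc3)cc2C(=O)OCC)c1` differs from compound 3 in one place: ethyl in place of hydrogen on an oxygen next to a carbonyl group. Among the compounds with values here, no measured pair isolates this change. Still, the ester in compound 2 sits at the low end of the numbers shown, so a drop in number, beyond the scatter, is expected for the step of an 8.7-fold lower number from compound 3 to compound 4 (0.94 log units; beyond the scatter). Compound 4 is estimated to give 3000 nM in this assay, with a likely range from 800 nM to 12000 nM.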

Compound 4, half-maximal inhibitory concentration: 7800 nM
Compound 4: the middle estimate sits 2.6-fold (0.41 log units) below what was measured; the range from low to high includes it.
By their numbers in this assay, from the lowest: compound 2; then compound 4; then compound 3. At a limit, above all of these: compound 1.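

Changing carboxy to ethoxycarbonyl at this position now has a measured size of its own in this assay: the change gives a 3.3-fold lower number from compound 3 to compound 4 (0.52 log units; beyond the scatter), a modest gain rather than a large one. With the ethyl ester on both sides, swapping chloromethyl for prop-1-en-1-yl on the carbonyl carbon gives a 20-fold higher number from compound 2 to compound 4 (1.29 log units; beyond the scatter), a large change, so the ester alone does not account for the low number of the chloromethyl compound. Nothing shown here explains the size of either step.

As far as these compounds go, it remains open whether a methyl ester, a longer chain on this oxygen or a primary amide in place of the ester would go the same way. Also open, from the compounds shown here alone, is how the carboxylic acid would read with chloromethyl on the carbonyl carbon.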